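Swapping 4-fluorophenyl for 3,4,5-trimethoxyphenyl in compound 3

The source may report more compounds than this note shows. Statements on the series, on what has been measured and on what is new or still open speak of the compounds shown alone.

Measured so far in a functional assay on A549 cells (Homo sapiens) for antiproliferative activity, read by MTT assay, with a stated time of 48 h (on this read-out lower numbers stand for stronger inhibition and higher numbers for weaker inhibition), for this series:
- compound 1 `O=C(/C=C\Nc1ccc(F)cc1)c1cn(-c2ccccc2)nc1-c1ccc(F)cc1` gives 5780 nM
- compound 2 `O=C(/C=C\Nc1ccc(F)cc1)c1cn(-c2ccccc2)nc1-c1ccc(Cl)cc1` gives > 50000 nM as a limit of the assay
- compound 3 `COc1ccc(-c2nn(-c3ccccc3)cc2C(=O)/C=C\Nc2ccc(F)cc2)cc1` gives 3980 nM

Compound 3 lies within the scatter of compound 1, and a 1.5-fold lower number from compound 1 to compound 3 (0.16 log units; within the scatter) confirms this. The entry for compound 2 is only a limit and not a number. Against that limit, an at least 12-fold lower number from compound 2 to compound 3 (1.09 log units; beyond the scatter) is a large step and lies beyond the scatter.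

Compound 4 `COc1ccc(-c2nn(-c3ccccc3)cc2C(=O)/C=C\Nc2cc(OC)c(OC)c(OC)c2)cc1` carries 3,4,5-trimethoxyphenyl in place of 4-fluorophenyl on an amine nitrogen and otherwise matches compound 3. Among the compounds with values here, no measured step touches this group, so the evidence is indirect. The three measured steps all exchange one group on an aromatic carbon. Of these, a 1.5-fold lower number from compound 1 to compound 3 (0.16 log units; within the scatter) stays within the scatter, while an at least 8.6-fold higher number from compound 1 to compound 2 (0.93 log units; beyond the scatter) goes beyond it. A single exchange in this series can therefore do nothing or a great deal, and the data give no direction for this one.

The working expectation stays near compound 3 at 3980 nM with wide margins. The estimated step is a 1.3-fold lower number from compound 3 to compound 4 (0.12 log units; within the scatter) and no shift beyond the scatter is expected. In this assay compound 4 is estimated at 3000 nM with an expected range from 500 nM to 20000 nM for now.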

Compound 4, half-maximal inhibitory concentration: 11200 nM
The estimate for compound 4 lay 3.7-fold (0.57 log units) below the measured number, within the range that was stated.
By their numbers in this assay, from the lowest: compounds 3, 1 and 4 (each within the scatter of the next, the first and the last beyond it). At a limit, above all of these: compound 2.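

In this assay, within the data shown here, the group on the amine nitrogen is changed for the first time, and 3,4,5-trimethoxyphenyl in place of 4-fluorophenyl gives a 2.8-fold higher number from compound 3 to compound 4 (0.45 log units; beyond the scatter). This position is therefore not silent, although compound 4 still gives a real number, 11200 nM, rather than a limit of the assay. Among these compounds, the single exchange removes the fluorine and brings in three methoxy groups with their 3 hydrogen-bond acceptors at once, so these parts of the change cannot be told apart, and nothing at hand bears on the cause of this step.

Among the compounds shown here, with only two groups compared on the amine nitrogen, no trend can be drawn, and it remains open whether plain phenyl or 4-methoxyphenyl there would give a number closer to that of compound 3 or to that of compound 4. Also open, on these data alone, is how this position would respond to a group of another kind, such as a saturated alkyl chain, a morpholine or a carboxylic acid in place of the aromatic ring.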